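Fluoro for methyl on an unmeasured pair of limits

This account rests on a few compounds, and the source may have more. Where it says the series, first, only, none or still open, it means among the compounds named here.

Compound 1, `CC(=O)Nc1ccc(-n2nncc2CN2C(=O)C3(C(C#N)=C(N)Oc4c(N)cc5nc6ccccc6nc5c43)c3ccccc32)cc1`: in a functional assay on MCF7 cells (Homo sapiens) for antiproliferative activity, read by MTT assay, with a stated time of 48 h (on this read-out higher numbers stand for weaker inhibition and lower numbers for stronger inhibition), compound 1 gives > 50000 nM, which is a limit of the assay and not a number.
Compound 2, `Cc1ccc(-n2nncc2CN2C(=O)C3(C(C#N)=C(N)Oc4c(N)cc5nc6ccccc6nc5c43)c3ccccc32)cc1Cl`: in this assay compound 2 gives > 50000 nM, again a limit rather than a number.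

Among the compounds with values here, compound 2 therefore stands at the limit, and the one step that leads to it, a step that the two limits leave unreadable from compound 1 to compound 2, cannot be read in size or direction. Compound 3, `N#CC1=C(N)Oc2c(N)cc3nc4ccccc4nc3c2C12C(=O)N(Cc1cnnn1-c1ccc(F)c(Cl)c1)c1ccccc12`, differs from compound 2 by fluoro in place of methyl on an aromatic carbon; cut one bond further out, this reads 3-chloro-4-methylphenyl to 3-chloro-4-fluorophenyl. Within the data shown here, no measured step bears on this change, and both known values sit at the limit of > 50000 nM in this assay, at which 2 of the 2 values shown sit. The account thus has no footing for a readable step in this assay and expects compound 3 to stay at the limit, with an estimated step that the limit leaves unreadable from compound 2 to compound 3. The estimate for compound 3 is 60000 nM, between 20000 nM and 200000 nM.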

Compound 3, half-maximal inhibitory concentration: 17800 nM
Compound 3: middle estimate off by 3.4-fold (0.53 log units), on the high side, outside the stated range (below it).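

On the 3-chloro-4-methylphenyl group, fluoro in place of methyl on the aromatic carbon ortho to a chloro group gives a readable number in this assay, with an at least 2.8-fold lower number from compound 2 to compound 3 (0.44 log units; beyond the scatter); this position therefore responds to a change of a single heavy atom. Set against the 4-acetamidophenyl group on the aromatic nitrogen, the 3-chloro-4-fluorophenyl group gives an at least 2.8-fold lower number from compound 1 to compound 3 (0.44 log units; beyond the scatter). Both steps are bounds rather than full sizes, and compound 3 alone leaves the limit of the assay: the limit of > 50000 nM in this assay, at which 2 of the 3 values shown sit.

From the compounds shown here alone, the true distance of compound 1 and compound 2 from compound 3 remains open, and the step from compound 1 to compound 2 cannot be read. Going by these compounds, whether hydrogen, methoxy or a second chloro group on that same carbon would also lower the number stays open too, as does whether the step needs the chloro group.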